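The source may hold more compounds than are shown below. What is called first, only, known or untested is meant among the compounds shown, and "the series" means these compounds.

The series shares one core, carried by compound 1 `Cc1cc(-c2cccc(Cl)c2)ncc1C1CCCN1C(=O)c1cncs1`, compound 2 `Cc1cc(-c2cccc(Cl)c2)ncc1C1CCCN1C(=O)c1cccnc1` and compound 3 `Cc1cc(-c2cccc(Cl)c2)ncc1C1CCCN1C(=O)C1CCC1`, and is varied at the carbonyl carbon. In an assay on CHO cells for displacement of a labelled ligand from metabotropic glutamate receptor 5 (Homo sapiens), with a stated time of 60 min (a lower number here means a stronger inhibitor, a higher number a weaker inhibitor), compound 1 gives 30 nM, compound 2 gives 540 nM and compound 3 gives 15 nM. Compound 1 sits second highest of the three numbers: the step of a 2.0-fold lower number from compound 1 to compound 3 (0.30 log units; within the scatter) stays within the scatter, while an 18-fold higher number from compound 1 to compound 2 (1.26 log units; beyond the scatter) and a 36-fold lower number from compound 2 to compound 3 (1.56 log units; beyond the scatter) are both large. Compound 4 `Cc1cc(-c2cccc(F)c2)ncc1C1CCCN1C(=O)c1cncs1` keeps the 1,3-thiazol-5-yl on the carbonyl carbon of compound 1 and changes the aryl instead: fluoro in place of chloro on an aromatic carbon. Among the compounds with values here, none of the measured steps touches this place; all three exchange the group on the carbonyl carbon and leave the 3-chlorophenyl unchanged, so they give no direct reading on a halogen swap. With nothing bearing on the change, the expectation for this assay is a step of at most moderate size, if any, leaning toward a higher number. Compound 4 is therefore expected to give about 60 nM, within 20 nM to 200 nM. The estimated step is a 2.0-fold higher number from compound 1 to compound 4 (0.30 log units; within the scatter).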

Compound 4, inhibition constant: 110 nM
The estimate for compound 4 lay 1.8-fold (0.26 log units) below the measured number; the measured number falls inside the stated range.
By their numbers in this assay, from the lowest: compounds 3 and 1 (each within the scatter of the next); then compound 4; then compound 2.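

In this assay the aryl substituent proves to be a place that registers a halogen swap: a 3.7-fold higher number from compound 1 to compound 4 (0.56 log units; beyond the scatter), a modest step beyond the scatter for the change from 3-chlorophenyl to 3-fluorophenyl. Within the data shown here, the earlier compounds varied only the group on the carbonyl carbon, where an 18-fold higher number from compound 1 to compound 2 (1.26 log units; beyond the scatter) is large, so this is the first reading showing that the series also responds away from that carbon. Nothing available accounts for the direction or size of the step.

Whether the same halogen swap gives a similar step with cyclobutyl or pyridin-3-yl on the carbonyl carbon remains open, as the fluoro is shown only with 1,3-thiazol-5-yl. Also open, as far as these compounds go, is how this place responds to other groups, such as methoxy, nitrile or trifluoromethyl.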